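This account rests on a few compounds, and the source may have more. Where it says the series, first, only, none or still open, it means among the compounds named here.

Measured in a functional assay on a cell-free system (Platelet, plasma, Homo sapiens) for inhibition; a higher number here means a weaker inhibitor, a lower number a stronger inhibitor:

Compound 1 `Cc1ccc(N(CCN2CCC(OCC(=O)O)CC2)C(=O)c2ccc(C(F)(F)F)cc2)cc1`: > 10000 nM (a limit of the assay)
Compound 2 `Cc1ccc(N(CCN2CCC(OCC(=O)O)CC2)C(=O)c2cccc(F)c2)cc1`: 160 nM

For the measured compounds named here, compound 2, at 160 nM, holds the only actual number so far. The result for compound 1 is a limit. Compound 3 `Cc1ccc(N(CCN2CCC(OCC(=O)O)CC2)C(=O)c2cccc(C(F)(F)F)c2)cc1` carries trifluoromethyl in place of fluoro on an aromatic carbon, meta to a large group (trifluoromethyl in place of fluoro on an aromatic carbon). Going by the values given here, one measured step bears on this: an at least 62-fold lower number from compound 1 to compound 2 (1.79 log units; beyond the scatter). That step is large and beyond the scatter, but its size is only a bound, resting on (the limit of > 10000 nM in this assay, at which 1 of the 2 values shown sits). It also swaps both the group and its place, so it cannot show what the group alone does. Trifluoromethyl is shared with compound 1, so a moderate move towards a higher number is expected, well short of that step. The estimated change is a 2.8-fold higher number from compound 2 to compound 3 (0.45 log units; beyond the scatter) in this assay. Compound 3 is expected at 450 nM, within an estimated range of 100 nM to 3000 nM.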

Compound 3, half-maximal inhibitory concentration: 20000 nM
Beside the measured number, compound 3's estimate is 44-fold (1.65 log units) below it; the whole stated range lies below it.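

With the place held fixed, trifluoromethyl in place of fluoro on an aromatic carbon gives a 130-fold higher number from compound 2 to compound 3 (2.10 log units; beyond the scatter) in this assay. Unlike the earlier step, which changed both the group and its place and whose size was only a bound, this step changes the group alone and has a readable size, so at this position the choice between fluoro and trifluoromethyl by itself separates a stronger inhibitor from a much weaker one. Whether moving trifluoromethyl matters stays unresolved, because the step from compound 1 to compound 3 cannot be read: the limit of > 10000 nM in this assay, at which 1 of the 3 values shown sits.

From the compounds shown here alone, what a chloro, methyl or methoxy group would give at this place remains open, as does the same ring with no group on it. Also open, going by these compounds, is how fluoro would fare at the ring's other places.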